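Thiazoline for oxazoline on the sulfonyl side chain

The source may hold more compounds than are shown below. What is called first, only, known or untested is meant among the compounds shown, and "the series" means these compounds.

Measured so far in a functional assay, tested at 75 ug/mL; a lower number here means a weaker effect, a higher number a stronger effect of the compound at the concentration tested:
compound 1 `O=S(=O)(CC1=NCCO1)C1C(c2ccc(Cl)cc2)=NN(c2ccccc2)C1c1ccc(Cl)cc1` — compound 1 gives "not active" (no number reported)
compound 2 `COc1ccc(C2=NOC(c3ccc(C)cc3)C2S(=O)(=O)CC2=NCCO2)cc1` — compound 2 gives 66.6%
compound 3 `COc1ccc(-c2noc(-c3ccc(C)cc3)c2S(=O)(=O)CC2=NCCS2)cc1` — compound 3 gives "not active" (no number reported)

Going by the values given here, compound 2 holds the only number in this assay; compound 1 and compound 3 return no figure. Compound 4 `COc1ccc(C2=NOC(c3ccc(C)cc3)C2S(=O)(=O)CC2=NCCS2)cc1` carries a group of 5 heavy atoms (3 carbon, 1 nitrogen, 1 sulfur; one five-membered non-aromatic ring with 2 hetero atoms) in place of a group of 5 heavy atoms (3 carbon, 1 nitrogen, 1 oxygen; one five-membered non-aromatic ring with 2 hetero atoms), on a saturated chain carbon bound to a sulfonyl sulfur. Compound 3 holds the same entering ring on a different core and gives no figure, which is the only hint on this ring. Among the compounds with values here, no step between measured compounds exists. The step from compound 2 to compound 4 is therefore expected to be a loss beyond the scatter, estimated as a number 21.6 percentage points lower from compound 2 to compound 4 (beyond the scatter). For compound 4 in this assay the expected value is 45%, with a range from 10% to 75%, and a fair chance that only a limit is reported.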

Compound 4, a percentage reported as activity, at one concentration (the size of the read-out at that concentration, not a potency): 49.7%
The estimate for compound 4 lay 4.7 percentage points below the measured number, within the range that was stated.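

In this assay, going by these compounds alone, the five-membered non-aromatic ring with sulfur in place of the one with oxygen, on a saturated chain carbon bound to a sulfonyl sulfur, gives a number 16.9 percentage points lower from compound 2 to compound 4 (beyond the scatter) and is the first readable step at this position. The change lowers the read-out without abolishing it: compound 4 still gives 49.7% at the concentration tested. No measurement at hand bears on the reason for this step.

Open, on these data alone, is how far this position tolerates groups outside this ring type, such as an open-chain amine or a carboxylic acid. Open too, as far as these compounds go, is whether the step holds on another core.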